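Fluoro to trifluoromethyl on the pendant aryl ring

This account rests on a few compounds, and the source may have more. Where it says the series, first, only, none or still open, it means among the compounds named here.

In a functional assay on MCF7 cells (Homo sapiens) for inhibition, read by sulforhodamine B assay, with a stated time of 72 h (a lower number here means a stronger inhibitor, a higher number a weaker inhibitor), compound 2 `COc1ccc2cc(C(C)c3nnc4n3N=C(c3ccc(F)cc3)CS4)ccc2c1` gives 15800 nM, the highest of the three numbers in hand. Compound 1 `COc1ccc2cc(C(C)c3nnc4n3N=C(c3ccc(OC(F)(F)F)cc3)CS4)ccc2c1` gives 8800 nM, and compound 3 `CC(c1ccc(-c2ccccc2)c(F)c1)c1nnc2n1N=C(c1ccc(C(F)(F)F)cc1)CS2` gives 4300 nM; compound 3 gives a lower number than compound 2, whereas compound 1 and compound 2 fall within the scatter of each other. Among the measured compounds shown here, the only single-place step measured, a 1.8-fold higher number from compound 1 to compound 2 (0.25 log units; within the scatter), swaps trifluoromethoxy for fluoro on the same aromatic carbon and stays within the scatter. Compound 4 `COc1ccc2cc(C(C)c3nnc4n3N=C(c3ccc(C(F)(F)F)cc3)CS4)ccc2c1` differs from compound 2 by trifluoromethyl in place of fluoro on an aromatic carbon. Compound 3 also carries a trifluoromethyl group, but differs from compound 4 elsewhere in the structure, so its value bears on compound 4 only loosely. For the measured compounds named here, with one within-scatter step as the sole direct precedent, at most a modest move toward a lower number is expected, in line with compound 1 at 8800 nM. Compound 4 is therefore expected to give 8000 nM, with a range from 3500 nM to 18000 nM. This estimate amounts to an expected 2.0-fold lower number from compound 2 to compound 4 (0.30 log units; within the scatter).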

Compound 4, half-maximal inhibitory concentration: 6900 nM
Beside the measured number, compound 4's estimate is 1.2-fold (0.06 log units) above it; the measured number falls inside the stated range.
By their numbers in this assay, from the lowest: compounds 3, 4, 1 and 2 (each within the scatter of the next, the first and the last beyond it).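

In this assay, among the compounds shown here, trifluoromethyl in place of fluoro on the aromatic carbon para to a large group gives the first step at this position beyond the scatter, though only a modest one (a 2.3-fold lower number from compound 2 to compound 4 (0.36 log units; beyond the scatter)). Trifluoromethyl and trifluoromethoxy, by contrast, cannot be told apart at this position (a 1.3-fold lower number from compound 1 to compound 4 (0.11 log units; within the scatter)), and trifluoromethoxy also stays within the scatter of fluoro, so only the two ends of this short set separate. Nothing at hand explains the difference between fluoro and trifluoromethyl.

Only fluorine-bearing groups stand at this position in the compounds shown, so how an amine, a carboxylic acid or a plain hydrogen there would read remains open. Going by these compounds, whether the change from 4-fluorophenyl to 4-(trifluoromethyl)phenyl behaves alike on the core of compound 3 also remains open.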